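This account rests on a few compounds, and the source may have more. Where it says the series, first, only, none or still open, it means among the compounds named here.

Measured compounds in a functional assay on CHO cells with adenosine receptor A1 (Homo sapiens) as the target, read by cAMP accumulation and immunoassay, with a stated time of 6 min, tested at 10 uM; a higher number here means a weaker effect of the compound at the concentration tested, a lower number a stronger effect:
compound 1 `Nc1scc(CN2CCN(c3ccncc3)CC2)c1C(=O)c1ccc(Cl)cc1` gives -15%
compound 2 `Nc1scc(CN2CCN(c3ccc(C(F)(F)F)cc3)CC2)c1C(=O)c1cccc(C(F)(F)F)c1` gives -47%
compound 3 `Nc1scc(CN2CCN(c3cccc(F)c3)CC2)c1C(=O)c1ccc(Cl)cc1` gives -82%

Compound 1 shows the highest number of the three, and both gaps to the others lie beyond the scatter, so it has the weakest effect here. Compound 4 `Nc1scc(CN2CCN(c3ccc(Cl)c(Cl)c3)CC2)c1C(=O)c1ccc(Cl)cc1` has not yet been tested; it differs from compound 1 by 3,4-dichlorophenyl in place of pyridin-4-yl on an amine nitrogen in a ring. Going by the values given here, the one measured step that bears on this is a number 67 percentage points lower from compound 1 to compound 3 (beyond the scatter), where a phenyl ring bearing a halogen also replaced pyridin-4-yl on the same ring nitrogen. Compound 2 likewise carries a plain phenyl ring in this position and gives a lower number than compound 1. A large downward step is therefore expected, a number 55 percentage points lower from compound 1 to compound 4 (beyond the scatter). Compound 4 is estimated at -70%, within -95% to -40%.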

Compound 4, a percentage reported as activity, at one concentration (the size of the read-out at that concentration, not a potency): -62%
For compound 4 the middle estimate is 8 percentage points below the measured one, within the range that was stated.
By their numbers in this assay, from the lowest: compound 3; then compound 4; then compound 2; then compound 1.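

With a number 47 percentage points lower from compound 1 to compound 4 (beyond the scatter) in this assay, a second halogen-bearing phenyl ring on the amine nitrogen gives a large drop from pyridin-4-yl, so this drop is not confined to the 3-fluorophenyl of compound 3. The position also separates these two phenyl rings, with a number 20 percentage points higher from compound 3 to compound 4 (beyond the scatter), so the 3,4-dichlorophenyl group gives the weaker effect of the pair. Nothing available explains either step.

The compounds shown leave open how an unsubstituted phenyl or a 4-chlorophenyl group would compare with these two rings. Also open, on these data alone, is whether a phenyl ring carrying an amine or a carboxylic acid would keep the lower number.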